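Swapping the Selenium-Bearing Chain of Compound 1

This account rests on a few compounds, and the source may have more. Where it says the series, first, only, none or still open, it means among the compounds named here.

Compound 1 `COc1ccc(N(C)c2nc(C)nc3ccccc23)cc1OCCC[Se]C#N`: 382 nM
Compound 2 `C[Se]c1ccc(N(C)c2nc(C3CC3)nc3ccccc23)cc1`: 13 nM

Both compounds were tested in a functional assay on A549 cells (Homo sapiens) for inhibition, read by MTT assay, with a stated time of 48 h; on this read-out lower numbers stand for stronger inhibition and higher numbers for weaker inhibition. Compound 1 has the higher of the two numbers, and so the weaker inhibition, with a gap to compound 2 that lies beyond the usual scatter. Compound 3 `COc1ccc(N(C)c2nc(C)nc3ccccc23)cc1C(=O)OCC[Se]C#N` keeps the core of compound 1 and changes one side chain, on an aromatic carbon ortho to a methoxy group: a group of 8 heavy atoms (4 carbon, 1 nitrogen, 2 oxygen, 1 selenium; no ring) in place of a group of 7 heavy atoms (4 carbon, 1 nitrogen, 1 oxygen, 1 selenium; no ring), on an aromatic carbon. The new group is only slightly larger and, like the old one, has no ring. Going by the values given here, no measured pair shows what such a swap does, so only a small change is expected in this assay, with no clear direction and nothing beyond the scatter. The expected change is a 1.3-fold higher number from compound 1 to compound 3 (0.12 log units; within the scatter). For compound 3 the estimate is 500 nM, with an expected range of 150 nM to 1800 nM.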

Compound 3, half-maximal inhibitory concentration: 353 nM
Estimate against measurement, compound 3: 1.4-fold (0.15 log units) above; low and high end bracket the measured number.
By their numbers in this assay, from the lowest: compound 2; then compounds 3 and 1 (each within the scatter of the next).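

At this position, on an aromatic carbon ortho to a methoxy group, this assay shows a 1.1-fold lower number from compound 1 to compound 3 (0.03 log units; within the scatter) when the group of 7 heavy atoms is replaced by the group of 8 heavy atoms. This is the first pair shown that differs in one place, and it shows that this chain can take on a double bond and a third hydrogen-bond acceptor with no difference beyond the scatter in this assay for this pair. No measured data are available to explain this result.

From the compounds shown here alone, both chains carry the same selenium and nitrile, so it remains open whether these atoms matter here, or how an amine or a carboxylic acid would fare in their place. Compound 2 differs from compound 1 and compound 3 in more than one place, so it cannot settle either question.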